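Oxadiazole for Ethoxymethyl on a Desmethyl Core

This account rests on a few compounds, and the source may have more. Where it says the series, first, only, none or still open, it means among the compounds named here.

Of the compounds shown here, three sharing one core have been measured in an ADME assay on the whole organism (Rattus norvegicus, strain Fischer 344) for pharmacokinetics, at a dose of 3 mg/kg by the oral route; on this read-out lower numbers stand for lower exposure and higher numbers for higher exposure at the dose given. Compound 2 `CCOCCOC[C@H]1CCCN(c2cc(C)nc3sc(C(N)=O)c(N)c23)C1` gives 909 nM. Compound 1 `Cc1cc(N2CCC[C@H](COCc3nc(C)no3)C2)c2c(N)c(C(N)=O)sc2n1` gives 451 nM in this assay, and compound 3 `CCOCCOC[C@H]1CCCN(c2ccnc3sc(C(N)=O)c(N)c23)C1` gives 2120 nM, the highest of the three numbers, with its nearest neighbour compound 2 and its furthest compound 1. Compound 1 differs from compound 2 by 3-methyl-1,2,4-oxadiazol-5-yl in place of ethoxymethyl on a saturated chain carbon bound to an oxygen on a saturated carbon, a change that brought a 2.0-fold lower number from compound 2 to compound 1 (0.30 log units; within the scatter). Compound 3 differs from compound 2 by hydrogen in place of methyl on an aromatic carbon, a change that brought a 2.3-fold higher number from compound 2 to compound 3 (0.37 log units; beyond the scatter).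

Compound 4 `Cc1noc(COC[C@H]2CCCN(c3ccnc4sc(C(N)=O)c(N)c34)C2)n1` is not yet measured in this assay. It differs from compound 3 by 3-methyl-1,2,4-oxadiazol-5-yl in place of ethoxymethyl on a saturated chain carbon bound to an oxygen on a saturated carbon, the same change that turns compound 2 into compound 1, made on a core that differs from that of compound 2 by hydrogen in place of methyl on an aromatic carbon. Among the compounds shown, this change appears twice in all, and the one measured instance gave a 2.0-fold lower number from compound 2 to compound 1 (0.30 log units; within the scatter), a step that stays within the scatter. A step of about the same size is expected from compound 3 to compound 4, and that expectation rests only on the step of a 2.0-fold lower number from compound 2 to compound 1 (0.30 log units; within the scatter) and on compound 3 standing at 2120 nM. The expected step for compound 4 is therefore a 2.0-fold lower number from compound 3 to compound 4 (0.31 log units; beyond the scatter). In this assay compound 4 is expected to give about 1050 nM, most likely between 500 nM and 2300 nM.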

Compound 4, maximal plasma concentration: 393 nM
Beside the measured number, compound 4's estimate is 2.7-fold (0.43 log units) above it, outside the stated range (below it).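

The exchange of ethoxymethyl for 3-methyl-1,2,4-oxadiazol-5-yl gave a 5.4-fold lower number from compound 3 to compound 4 (0.73 log units; beyond the scatter) in this assay, so on this core the change did not carry over at the size seen on the core bearing the methyl: the same change on two cores in this assay, a 2.0-fold lower number (0.30 log units; within the scatter) from compound 2 to compound 1 and a 5.4-fold lower number (0.73 log units; beyond the scatter) from compound 3 to compound 4, 2.7-fold (0.43 log units) apart, beyond the scatter of two such steps. Read the other way, hydrogen in place of methyl on an aromatic carbon, with the oxadiazole present, came to a 1.1-fold lower number from compound 1 to compound 4 (0.06 log units; within the scatter), and the higher number that this change gave with the ethoxymethyl group did not reappear: the same change on two cores in this assay, a 2.3-fold higher number (0.37 log units; beyond the scatter) from compound 2 to compound 3 and a 1.1-fold lower number (0.06 log units; within the scatter) from compound 1 to compound 4, 2.7-fold (0.43 log units) apart, beyond the scatter of two such steps. These four compounds show that in this series the size of each step depends on what stands at the other place, but they form a single square, so they do not show why, or how either change would behave on any further core.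

The compounds shown leave open whether this dependence extends to other replacements for ethoxymethyl, such as a longer chain, an amine or a carboxylic acid, or to other groups in place of methyl on the aromatic carbon, such as ethyl or chlorine. They also leave open whether the same pattern would hold at another oral dose.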